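The source may report more compounds than this note shows. Statements on the series, on what has been measured and on what is new or still open speak of the compounds shown alone.

Three members of this series have been measured in a functional assay on A549 cells (Homo sapiens) for antiproliferative activity, read by MTT assay, with a stated time of 48 h; a higher number here means a weaker inhibitor, a lower number a stronger inhibitor. Compound 1 `CC(C)=CCC[C@]1(C)/C=C/[C@@H](OC(=O)C=C(C)C)[C@](C)(O)/C=C/C(=O)/C(CN2CCCC2)=C\C1` gives 180 nM, compound 2 `CC[Si](CC)(CC)C/C1=C/C[C@](C)(CCC=C(C)C)/C=C/[C@@H](OC(=O)C=C(C)C)[C@](C)(O)/C=C/C1=O` gives 3100 nM, and compound 3 `CC(C)=CCC[C@]1(C)/C=C/[C@@H](OC(=O)C=C(C)C)[C@](C)(O)/C=C/C(=O)/C(COC(=O)c2ccc([N+](=O)[O-])cc2)=C\C1` gives 1310 nM. Compound 2 thus carries the highest number of the three, with compound 3 nearest and compound 1 furthest. Compound 4 `CC(C)=CCC[C@]1(C)/C=C/[C@@H](OC(=O)C=C(C)C)[C@](C)(O)/C=C/C(=O)/C(C(=O)N(C(C)C)C(C)C)=C\C1` is next for measurement; relative to compound 2 the change is a group of 9 heavy atoms (7 carbon, 1 nitrogen, 1 oxygen; no ring) in place of a group of 8 heavy atoms (7 carbon, 1 silicon; no ring), on a double-bonded ring carbon. Both measured steps that exchange the silicon-bearing group bear on this: a 17-fold higher number from compound 1 to compound 2 (1.24 log units; beyond the scatter) and a 2.4-fold lower number from compound 2 to compound 3 (0.37 log units; beyond the scatter). Each such exchange so far gave a lower number, so a lower number is expected for compound 4, its size uncertain because a 7.3-fold higher number from compound 1 to compound 3 (0.86 log units; beyond the scatter) shows the entering group itself matters. Compound 4 is estimated at 600 nM, range 150 nM to 2500 nM. This corresponds to an expected 5.2-fold lower number from compound 2 to compound 4 (0.71 log units; beyond the scatter).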

Compound 4, half-maximal inhibitory concentration: 13500 nM
Estimate against measurement, compound 4: 23-fold (1.35 log units) below; the measured number lies above the stated range.
By their numbers in this assay, from the lowest: compound 1; then compound 3; then compound 2; then compound 4.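

Exchanging the silicon-bearing group does not always lower the number: diisopropylcarbamoyl on this double-bonded ring carbon gives a 4.4-fold higher number from compound 2 to compound 4 (0.64 log units; beyond the scatter), opposite in direction to the exchanges that gave compound 1 and compound 3. Against the amine of compound 1, the same group gives a 75-fold higher number from compound 1 to compound 4 (1.88 log units; beyond the scatter), so this position spans a wide range of values across the four compounds. Nothing measured here accounts for the rise. Still open, going by these compounds, is whether the carbonyl bound directly to the ring carbon or the two isopropyl groups on nitrogen drive this result; pyrrolidin-1-ylcarbonyl or a carboxylic acid at this carbon would help separate them.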